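Two Dimethoxy Compounds and a Proposed Methylamide

The source may report more compounds than this note shows. Statements on the series, on what has been measured and on what is new or still open speak of the compounds shown alone.

Measured values in a functional assay on NTUB1 cells (Homo sapiens) for cytotoxicity, read by MTT assay, with a stated time of 72 h (on this read-out higher numbers stand for weaker inhibition and lower numbers for stronger inhibition), are these
Compound 1 `COc1ccc(OC)c(C(=O)/C=C/c2ccc(C(=O)O)cc2)c1` gives 5700 nM
Compound 2 `CCCOC(=O)c1ccc(/C=C/C(=O)c2cc(OC)ccc2OC)cc1` gives 6010 nM

Compound 2 at 6010 nM stands level with compound 1 at 5700 nM, the two values lying within the scatter of each other. The next structure, compound 3 `CNC(=O)c1ccc(/C=C/C(=O)c2cc(OC)ccc2OC)cc1`, carries methylamino in place of propoxy on a carbonyl carbon, as methylamino in place of propoxy on a carbonyl carbon shows. Among the measured compounds shown here, one measured step bears on this, a 1.1-fold higher number from compound 1 to compound 2 (0.02 log units; within the scatter), and it also alters what the carbonyl carries. For the measured compounds named here, no measured compound holds methylcarbamoyl, so that step is only a loose guide. No change beyond the scatter is therefore expected in this assay, in either direction. The expected step is a 1.0-fold lower number from compound 2 to compound 3 (0.00 log units; within the scatter). For compound 3 the estimated value is 6000 nM, with an expected range from 2500 nM to 14000 nM.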

Compound 3, half-maximal inhibitory concentration: 2200 nM
The estimate for compound 3 lay 2.7-fold (0.44 log units) above the measured number, outside the stated range (below it).
By their numbers in this assay, from the lowest: compound 3; then compounds 1 and 2 (each within the scatter of the next).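

In this assay, the carbonyl carbon turned out not to be indifferent to what it carries: with methylamino in place of propoxy there was a 2.7-fold lower number from compound 2 to compound 3 (0.44 log units; beyond the scatter), and with methylamino in place of hydroxy there was a 2.6-fold lower number from compound 1 to compound 3 (0.41 log units; beyond the scatter). Hydroxy and propoxy had left the two earlier compounds within the scatter of each other, so only the third group on this carbon, and with it the change from propoxycarbonyl to methylcarbamoyl, has separated one compound from the others. Nothing available on these compounds accounts for this stronger inhibition.

As far as these compounds go, what a plain amino group, ethylamino or dimethylamino would do on this carbonyl carbon remains open. So does the question of whether the methyl on the nitrogen matters at all, or whether a longer chain there would keep the step.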